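The compounds below may be only part of what the source reports. "The series", "measured", "known", "first", "only" and "open" are said of these compounds alone.

Three thioureas built on a shared core have been tested for cytotoxicity, and a fourth awaits measurement. In a functional assay on B16-BL6 cells (Mus musculus) for cytotoxicity, read by MTT assay, with a stated time of 48 h (on this read-out higher numbers stand for weaker inhibition and lower numbers for stronger inhibition), compound 1 `CNC(=O)c1ccc(Sc2ccc(NC(=S)Nc3cc(C(F)(F)F)cc(C(F)(F)F)c3)cc2)nc1` gives 36100 nM. In this assay compound 3 `CNC(=O)c1ccc(Sc2ccc(NC(=S)Nc3ccc(Cl)c(C(F)(F)F)c3)cc2)nc1` gives 23500 nM. Compound 2 `CNC(=O)c1ccc(Sc2cccc(NC(=S)Nc3ccc(F)c(Cl)c3)c2)nc1` is different: in this assay compound 2 gives > 100000 nM, which is a limit of the assay and not a number. Among the values shown, compound 2 therefore stands at the limit of > 100000 nM in this assay, at which 1 of the 3 values shown sits, and only a bound, not a position, is known for it.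

Compound 4 `CNC(=O)c1ccc(Sc2cccc(NC(=S)Nc3ccc(F)c(F)c3)c2)nc1` differs from compound 2 in one place: fluoro in place of chloro on an aromatic carbon. Among the measured compounds shown here, no step between two measured compounds is available here, so nothing measured speaks for a shift in either direction. The expectation is that the change from compound 2 to compound 4 in this assay stays within the usual scatter, that is a step that the limit leaves unreadable from compound 2 to compound 4. Compound 4 is therefore expected to give about 150000 nM in this assay, somewhere between 60000 nM and 400000 nM, and most likely again only a limit rather than a number.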

Compound 4, half-maximal inhibitory concentration: 58200 nM
The estimate for compound 4 lay 2.6-fold (0.41 log units) above the measured number; measured number outside the range, below it.
By their numbers in this assay, from the lowest: compounds 3, 1 and 4 (each within the scatter of the next, the first and the last beyond it). At a limit, above all of these: compound 2.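

Fluoro in place of chloro on this aromatic carbon, ortho to a fluoro group, turns 3-chloro-4-fluorophenyl into 3,4-difluorophenyl, and in this assay this swap gives an at least 1.7-fold lower number from compound 2 to compound 4 (0.23 log units; that floor lies within the scatter). Compound 4 gives 58200 nM, a readable number. The real size of the step cannot be read, and it may be far larger than its floor, because compound 2 stands at a limit: the limit of > 100000 nM in this assay, at which 1 of the 4 values shown sits.

A single pair leaves open whether the same swap would act alike on another compound built on the shared core. On these data alone, how an amine, a methoxy group or a nitrile on this aromatic carbon would read in this assay also remains open.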